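Series notes: 2-carboxyethyl in place of 3-chlorophenyl

The source may hold more compounds than are shown below. What is called first, only, known or untested is meant among the compounds shown, and "the series" means these compounds.

Three measured members share one core. Compound 1 `O=c1c2ccccc2c(-c2cccnc2)nn1Cc1cccc(Cl)c1` gives 95% in an assay on isolated protein (Oryctolagus cuniculus) with Thromboxane-A synthase (Homo sapiens) as the target, tested at 1 uM; on this read-out higher numbers stand for more inhibition at the one concentration tested (going by the name of the read-out) and lower numbers for less inhibition. Compound 2 `COC(=O)c1ccc(Cn2nc(-c3cccnc3)c3ccccc3c2=O)cc1` gives 95% in this assay, level with compound 1 at the digits shown; together these are the lowest of the three numbers, with no change between them beyond the scatter. Compound 3 `O=c1c2ccccc2c(-c2cccnc2)nn1S(=O)(=O)c1ccccc1` gives 96% in this assay, the furthest from compound 1 yet still within the scatter. For the measured compounds named here, the three numbers leave no measured step to lean on.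

Compound 4 `O=C(O)CCCn1nc(-c2cccnc2)c2ccccc2c1=O` has not been measured. It differs from compound 1 as follows: 2-carboxyethyl in place of 3-chlorophenyl on a saturated chain carbon bound to an aromatic nitrogen. With the rest of compound 1 kept, the expected step of a number 10 percentage points lower from compound 1 to compound 4 (within the scatter) is downward but of modest size, as a small step at most is what the nearly saturated read-out of compound 1 at 95% leaves room for upward. Compound 4 is estimated at 85%, between 60% and 98%.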

Compound 4, a percentage reported as inhibition, at one concentration (the size of the read-out at that concentration, not a potency): 73%
Compound 4: middle estimate off by 12 percentage points, on the high side, within the range that was stated.
By their numbers in this assay, from the lowest: compound 4; then compounds 1, 2 and 3 (each within the scatter of the next).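

In this assay, for the compounds shown here, 2-carboxyethyl in place of 3-chlorophenyl on a saturated chain carbon bound to an aromatic nitrogen gives a number 22 percentage points lower from compound 1 to compound 4 (beyond the scatter) and provides the first measured step, so this position is not indifferent to what it carries. Compound 4 at 73% retains substantial inhibition, so the change lowers the read-out without abolishing it. No evidence at hand bears on the reason for this step.

On these data alone, whether the drop follows the carboxylic acid or the loss of the aromatic ring remains open. A methyl ester on the same chain, or a phenyl ring carrying a carboxylic acid, would separate the two.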